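Methoxy on the fused ring of compound 3: expected outcome

The source may hold more compounds than are shown below. What is called first, only, known or untested is meant among the compounds shown, and "the series" means these compounds.

Compound 1 `COC(=O)c1c(-c2ccc(OCc3ccccc3)cc2)oc2ccccc2c1=O` and compound 2 `COC(=O)c1c(-c2ccc(OCc3ccccc3)cc2)oc2ccc(OC)cc2c1=O` share a core and differ by methoxy in place of hydrogen on an aromatic carbon. In a functional assay on HT-29 cells (Homo sapiens) for cytotoxicity, read by MTT assay, with a stated time of 6 days (a lower number here means that less compound is needed, a higher number that more compound is needed for the effect), compound 1 gives only the assay limit > 25 ug/mL. Compound 2 gives 15.6 ug/mL in this assay, a step of an at least 1.6-fold lower number from compound 1 to compound 2 (0.20 log units; that floor lies within the scatter). Compound 3 `COC(=O)c1c(-c2ccc(O)cc2)oc2ccccc2c1=O` differs from compound 1 by hydrogen in place of benzyl on an oxygen on an aromatic ring; compound 3 gives only the limit > 25 ug/mL, so the step that the two limits leave unreadable from compound 1 to compound 3 cannot be sized. Two of the three measured values sit at the limit of > 25 ug/mL in this assay, at which 2 of the 3 values shown sit. Compound 4 `COC(=O)c1c(-c2ccc(O)cc2)oc2cc(OC)ccc2c1=O`, not yet measured, differs from compound 3 by methoxy in place of hydrogen on an aromatic carbon, the same change as that from compound 1 to compound 2. Because of an at least 1.6-fold lower number from compound 1 to compound 2 (0.20 log units; that floor lies within the scatter), the step of an at least 1.1-fold lower number from compound 3 to compound 4 (0.05 log units; that floor lies within the scatter) is expected to be of like size. Compound 4 is thus estimated at 22 ug/mL, between 10 ug/mL and 50 ug/mL, with a fair chance that only a limit results.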

Compound 4, concentration for half-maximal effect: 19.2 ug/mL
Compound 4: the middle estimate sits 1.1-fold (0.06 log units) above what was measured, and the stated range covers the measured number.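

In this assay, methoxy in place of hydrogen on an aromatic carbon gives an at least 1.3-fold lower number from compound 3 to compound 4 (0.11 log units; that floor lies within the scatter). Both steps start from a limit of the assay, not from a number: the limit of > 25 ug/mL in this assay, at which 2 of the 4 values shown sit. The lower number recurs on both cores, but with floors within the scatter this shows neither a reliable effect nor a size that carries from one core to the other: the same change on two cores in this assay, an at least 1.6-fold lower number (0.20 log units; that floor lies within the scatter) from compound 1 to compound 2 and an at least 1.3-fold lower number (0.11 log units; that floor lies within the scatter) from compound 3 to compound 4; the limit leaves it open whether they differ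

Going by these compounds, the true size of the step on either core stays open, and the step between compound 1 and compound 3 cannot be read. The compounds shown also leave open how an amine, a carboxylic acid or a longer chain in place of methoxy would behave on either core.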